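The compounds below may be only part of what the source reports. "The series", "measured", "known", "first", "only" and "open" are said of these compounds alone.

In an ADME assay on BHK-21 cells (Mesocricetus auratus) for cytotoxicity, with a stated time of 3 days (on this read-out higher numbers stand for lower toxicity in this test and lower numbers for higher toxicity in this test), compound 1 `CC(Sc1nnc(-c2ccncc2)s1)C(=O)Nc1c(Cl)cccc1Cl` reports a limit of the assay, > 50000 nM, and not a number. Compound 3 `CC(CSc1nnc(-c2ccncc2)s1)C(=O)NCc1ccccc1` likewise reaches a limit, > 50000 nM. Compound 2 `O=C(CSc1nnc(-c2ccncc2)s1)Nc1c(Cl)cccc1Cl` has no value of its own in this assay, recorded as "not determined" (no result reported); where it stands can only be set beside (the limit of > 50000 nM in this assay, at which 2 of the 3 values shown sit), the point at which the two measured values sit. Compound 4 `O=C(CSc1nnc(-c2ccncc2)s1)Nc1ccccc1Cl` is the partner to compound 2 in this account, differing by hydrogen in place of chloro on an aromatic carbon. No measured pair shows this change, so no step in this assay can be read off; given that the shown values are limits, a step beyond the scatter is not expected in either direction. Compound 4 is therefore estimated at 60000 nM, most likely again as a limit, with an expected range from 25000 nM to 150000 nM.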

Compound 4, half-maximal cytotoxic concentration: > 50000 nM
Compound 4: a limit, no number; the forecaster's own chance of this, stated with the estimate: 75%; the middle value is on the limit's open side.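

Within the data shown here, no step from compound 2 to compound 4 can be read in this assay. Compound 4 gives only a limit, > 50000 nM. The compounds shown leave open whether going from 2,6-dichlorophenyl to 2-chlorophenyl changes the cytotoxic concentration at all.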